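The source may hold more compounds than are shown below. What is called first, only, known or untested is meant among the compounds shown, and "the series" means these compounds.

Working notes on the shared core of compound 1 `Cc1cc(C)c(Oc2cc(Nc3ccc(C#N)cc3)ncc2C(=O)NCc2cn(Cc3ccccc3[N+](=O)[O-])nn2)c(C)c1`. In an ADME assay on MT4 cells (Homo sapiens) for cytotoxicity, read by MTT assay, with a stated time of 5 days (on this read-out higher numbers stand for lower toxicity in this test and lower numbers for higher toxicity in this test), compound 1 reaches only a limit of the assay, > 212000 nM. Compound 2 `Cc1cc(C)c(Oc2cc(Nc3ccc(C#N)cc3)ncc2C(=O)NCc2cn(Cc3ccccc3Cl)nn2)c(C)c1` likewise reaches only a limit in this assay, >= 188000 nM. Among the measured compounds shown here, compound 3 `COC(=O)Cn1cc(CNC(=O)c2cnc(Nc3ccc(C#N)cc3)cc2Oc2c(C)cc(C)cc2C)nn1` gives the single actual number in the set, 13800 nM. The steps of an at least 15-fold lower number from compound 1 to compound 3 (1.18 log units; beyond the scatter) and an at least 13-fold lower number from compound 2 to compound 3 (1.13 log units; beyond the scatter) both lie beyond the scatter and separate compound 3 from the limits the limit of > 212000 nM in this assay, at which 1 of the 3 values shown sits, and (the limit of >= 188000 nM in this assay, at which 1 of the 3 values shown sits); the step that the two limits leave unreadable from compound 1 to compound 2 cannot be read. Compound 4 `Cc1cc(C)c(Oc2cc(Nc3ccc(C#N)cc3)ncc2C(=O)NCc2cn(CCC#N)nn2)c(C)c1` differs from compound 3 by cyanomethyl in place of methoxycarbonyl on a saturated chain carbon bound to an aromatic nitrogen. For the measured compounds named here, no measured pair exchanges one small chain group for another at this position; the two readable steps describe the loss of an aryl group and carry no information on the size of a move from methoxycarbonyl to cyanomethyl. In this assay the expected step of a 1.4-fold higher number from compound 3 to compound 4 (0.16 log units; within the scatter) is therefore set as none beyond the scatter. Compound 4 is estimated at 20000 nM, with a range from 7000 nM to 60000 nM.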

Compound 4, half-maximal cytotoxic concentration: 40200 nM
Estimate against measurement, compound 4: 2.0-fold (0.30 log units) below; low and high end bracket the measured number.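

In this assay a move between two small chain groups at this position can itself be read, with a 2.9-fold higher number from compound 3 to compound 4 (0.46 log units; beyond the scatter) for cyanomethyl in place of methoxycarbonyl, so the position does not respond only to the loss of an aryl group. Cyanomethyl also stays apart from both aryl-bearing groups, with an at least 4.6-fold lower number from compound 2 to compound 4 (0.66 log units; beyond the scatter) and an at least 5.2-fold lower number from compound 1 to compound 4 (0.72 log units; beyond the scatter) for the exchange of 2-chlorophenyl and 2-nitrophenyl, so among these four compounds the small groups do not fall together at one level. Nothing measured here bears on what lies behind the step from methoxycarbonyl to cyanomethyl.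

The compounds shown change the methoxycarbonyl and the nitrile together, and which part of either group carries the step stays open. A carboxylic acid, a primary amine or a longer alkyl chain on this saturated chain carbon would show how wide the range among small groups runs.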